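The source may report more compounds than this note shows. Statements on the series, on what has been measured and on what is new or still open speak of the compounds shown alone.

Among the measured compounds shown here, in an ADME assay on J774.A1 cells (Mus musculus) for cytotoxicity, read by MTT assay, with a stated time of 72 h (on this read-out higher numbers stand for weaker inhibition and lower numbers for stronger inhibition), two compounds have numbers so far: compound 1 (`CCOc1cc(NC(=N)c2ccccn2)ccc1-c1ccc(-c2ccccc2)o1`) gives 6600 nM and compound 2 (`COc1cc(NC(=N)c2ccccn2)ccc1-c1ccc(-c2ccccc2)o1`) gives 9000 nM, which lie within the scatter of each other. The next compound is compound 3 (`N=C(Nc1ccc(-c2ccc(-c3ccccc3)o2)c(C(F)(F)F)c1)c1ccccn1`), with trifluoromethyl in place of methoxy on an aromatic carbon of the shared core: trifluoromethyl in place of methoxy on an aromatic carbon. For the measured compounds named here, the only measured step, a 1.4-fold higher number from compound 1 to compound 2 (0.13 log units; within the scatter), alters the chain on the oxygen but keeps the oxygen itself, so it bears only indirectly on this change. Going by the values given here, no measured step replaces that group outright, and the data set no direction for the exchange. With so little to go on, no shift beyond the scatter is expected in this assay, and the estimated step is a 1.3-fold lower number from compound 2 to compound 3 (0.11 log units; within the scatter). Compound 3 is expected at 7000 nM, with an estimated range of 2800 nM to 16000 nM.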

Compound 3, half-maximal inhibitory concentration: > 20000 nM
Compound 3: a limit, no number; the forecaster's own chance of this, stated with the estimate: 10%; middle value at least 2.8-fold (0.45 log units) away from the limit.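

In this assay, among the compounds shown here, the only earlier step at this position changed the chain on the oxygen and stayed within the scatter, whereas replacing the whole group on the aromatic carbon gives a change beyond it. Trifluoromethyl in place of methoxy gives an at least 2.2-fold higher number from compound 2 to compound 3 (0.34 log units; beyond the scatter), and trifluoromethyl in place of ethoxy gives an at least 3.0-fold higher number from compound 1 to compound 3 (0.48 log units; beyond the scatter), so this position is not indifferent to the exchange and both steps point the same way. The reading for compound 3 is a limit and not a number, which leaves the full size of both steps unknown: the limit of > 20000 nM in this assay, at which 1 of the 3 values shown sits.

With trifluoromethyl as the only group here that lacks the oxygen, the compounds shown do not separate the loss of the oxygen from the entry of the fluorines. A methyl, a chlorine or a hydroxyl at this position would bear on that, as would a longer chain on the oxygen.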